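Bromo to Chloro on Two Indole-Derived Terpenoid Cores

The source may hold more compounds than are shown below. What is called first, only, known or untested is meant among the compounds shown, and "the series" means these compounds.

Compound 1 `COC(=O)[C@@]1(C)CCC=C2[C@@H]1CC[C@@H](C)[C@]2(C)Cc1c(C)[nH]c2c(Br)cccc12`: 22000 nM
Compound 2 `COC(=O)[C@@]1(C)CCC=C2[C@@H]1CC[C@@H](C)[C@]2(C)Cc1c(C)[nH]c2c(Cl)cccc12`: 17000 nM
Compound 3 `COC(=O)[C@@]1(C)CC[C@@H]2C3=C1CC[C@@H](C)[C@]3(C)C[C@@H]1c3cccc(Br)c3N[C@H]21`: 22000 nM

Three compounds were measured in a functional assay on HeLa cells (Homo sapiens) for inhibition, read by sulforhodamine B assay, with a stated time of 48 h (a higher number here means a weaker inhibitor of growth, a lower number a stronger inhibitor of growth), and all three gave numbers of roughly the same size. Compound 1 and compound 2 share one core and differ by a single change, (chloro in place of bromo on an aromatic carbon). This change gave a 1.3-fold lower number from compound 1 to compound 2 (0.11 log units; within the scatter). Compound 3 has a different core; how its core differs from that of compound 1 is not broken down here. In this assay compound 3 gives 22000 nM, which stands level with compound 1 at the digits recorded, and within the scatter of compound 2.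

Compound 4 `COC(=O)[C@@]1(C)CC[C@@H]2C3=C1CC[C@@H](C)[C@]3(C)C[C@@H]1c3cccc(Cl)c3N[C@H]21` has not yet been measured. It is made from compound 3 by chloro in place of bromo on an aromatic carbon. The surroundings are not identical to those of the first pair: in compound 1 the aromatic carbon belongs to a fused or bridged system of two rings, while in compound 3 it belongs to a fused or bridged system of five rings, so this is the same kind of change rather than the same change. Because the earlier step gave a 1.3-fold lower number from compound 1 to compound 2 (0.11 log units; within the scatter), compound 4 is expected to differ little from compound 3, with an estimated step of a 1.2-fold lower number from compound 3 to compound 4 (0.09 log units; within the scatter). The estimate for compound 4 in this assay is 18000 nM, with a plausible range from 9000 nM to 40000 nM.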

Compound 4, concentration for 50% growth inhibition: 31000 nM
Compound 4: the middle estimate sits 1.7-fold (0.24 log units) below what was measured; measured number inside the range.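

In this assay, chloro in place of bromo on an aromatic carbon gave a 1.4-fold higher number from compound 3 to compound 4 (0.15 log units; within the scatter), so on this second core, too, the step stays inside the usual scatter of repeated measurements. Set beside the earlier step, the result on the second core does not separate from the result on the first: the same change on two cores in this assay, a 1.3-fold lower number (0.11 log units; within the scatter) from compound 1 to compound 2 and a 1.4-fold higher number (0.15 log units; within the scatter) from compound 3 to compound 4, 1.8-fold (0.26 log units) apart, within the scatter of two such steps

This shows that, for these two pairs, the change carries from one core to the other as a step too small to read, with the chloro and bromo compounds of each pair indistinguishable in this growth read-out; it does not show that the change truly acts in opposite directions on the two cores, since the printed directions cannot be told apart from scatter, nor does it show that the change would behave the same way on any other core in the series.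

The compounds shown carry only bromo or chloro at this aromatic carbon, which leaves open whether fluoro, methoxy or an amine there would give a step that can be read on either core. From the compounds shown here alone, it also remains open whether a carboxylic acid or an amide in place of the methyl ester would move the numbers on these cores.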